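Amino in place of hydrogen on compound 2

The compounds below may be only part of what the source reports. "The series", "measured", "known", "first", "only" and "open" are said of these compounds alone.

Measured in a functional assay on HCT-116 cells (Homo sapiens) for antiproliferative activity; a higher number here means a weaker inhibitor, a lower number a stronger inhibitor:
- compound 1 `COc1ccc(-c2snnc2-c2cc(OC)c(OC)c(OC)c2)cc1OC`: 50.9 nM
- compound 2 `COc1ccc(-c2snnc2-c2cc(OC)c(OC)c(OC)c2)cc1`: 25 nM

Of the two, compound 2 has the lower number in this assay, at 25 nM. The next change leads to compound 3 `COc1ccc(-c2snnc2-c2cc(OC)c(OC)c(OC)c2)cc1N`: amino in place of hydrogen on an aromatic carbon. In words, this is amino in place of hydrogen on an aromatic carbon, ortho to a methoxy group.

Among the measured compounds shown here, only one measured step bears on this carbon: a 2.0-fold lower number from compound 1 to compound 2 (0.31 log units; beyond the scatter). That step is modest and involves methoxy rather than amino. For the measured compounds named here, no amino compound has been measured, so the data give no direction. A step no larger than that modest one is expected, in either direction, and possibly none beyond the scatter. The estimate is a 1.1-fold lower number from compound 2 to compound 3 (0.06 log units; within the scatter). For compound 3 the expected value is 22 nM, with an estimated range of 6 nM to 80 nM.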

Compound 3, half-maximal inhibitory concentration: 3.7 nM
For compound 3 the middle estimate is 5.9-fold (0.77 log units) above the measured one; the whole stated range lies above it.
By their numbers in this assay, from the lowest: compound 3; then compound 2; then compound 1.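

At this carbon, ortho to a methoxy group, the group present matters more in this assay than the methoxy-to-hydrogen change alone could show: amino in place of hydrogen gives a 6.8-fold lower number from compound 2 to compound 3 (0.83 log units; beyond the scatter). Amino in place of methoxy on the same carbon gives a 14-fold lower number from compound 1 to compound 3 (1.14 log units; beyond the scatter), so the three groups run amino, hydrogen, methoxy from the lowest number to the highest, with each step beyond the scatter. No evidence is available on what lies behind this gain.

On these data alone, it remains open how hydroxyl, methylamino or acetylamino at this carbon would compare with amino. As far as these compounds go, it also remains open whether the amino gain would carry over to a core with a different set of methoxy groups on the other aromatic ring.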